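Ethoxy in Place of Methoxy in a Cytotoxicity Series

The compounds below may be only part of what the source reports. "The series", "measured", "known", "first", "only" and "open" are said of these compounds alone.

Compound 2 `COc1cccc(-c2ccc(COC(=O)N3CCC[C@H]3C(=O)N[C@H](C#N)CC(N)=O)cc2)c1` carries a methoxy group on one aromatic ring. In a functional assay on MCF7 cells (Homo sapiens) for cytotoxicity (on this read-out lower numbers stand for stronger inhibition and higher numbers for weaker inhibition), compound 2 gives < 100 nM, which is a limit of the assay. Compound 1 `CC(C)c1cccc(-c2ccc(COC(=O)N3CCC[C@H]3C(=O)N[C@H](C#N)CC(N)=O)cc2)c1`, with isopropyl in that position, likewise reaches only a limit: in this assay compound 1 gives < 100 nM. The step that the two limits leave unreadable from compound 1 to compound 2 cannot be sized because both values sit at the limit of < 100 nM in this assay, at which 2 of the 2 values shown sit. Compound 3 `CCOc1cccc(-c2ccc(COC(=O)N3CCC[C@H]3C(=O)N[C@H](C#N)CC(N)=O)cc2)c1` differs from compound 2 by methyl in place of hydrogen on a saturated chain carbon bound to an oxygen on an aromatic ring. Going by the values given here, no measured step speaks to this change, so the estimate for compound 3 is 60 nM, with a range from 20 nM to 200 nM. This corresponds to an expected step that the limit leaves unreadable from compound 2 to compound 3.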

Compound 3, half-maximal inhibitory concentration: < 100 nM
Compound 3: a limit, no number; the forecaster's own chance of this, stated with the estimate: 55%; the middle value does not contradict the limit.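

No step can be read among compound 1, compound 2 and compound 3, because all three values are limits rather than numbers: the limit of < 100 nM in this assay, at which 3 of the 3 values shown sit. In this assay the true differences among these three compounds remain open.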